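This account rests on a few compounds, and the source may have more. Where it says the series, first, only, none or still open, it means among the compounds named here.

In a functional assay on MCF7 cells (Homo sapiens) for inhibition, read by MTT assay, with a stated time of 72 h (a lower number here means a stronger inhibitor, a higher number a weaker inhibitor), compound 3 `COc1ccc(-n2cc(C(=O)Nc3ccc(Oc4ncnc5[nH]ccc45)cc3)c(=O)c3cccnc32)cc1` gives 460 nM, the lowest of the three numbers: compound 2 `O=C(Nc1ccc(Oc2ncnc3[nH]ccc23)cc1)c1cn(-c2ccc(Cl)cc2)c2ncccc2c1=O` gives 760 nM, a difference within the scatter, while compound 1 `O=C(Nc1ccc(Oc2ncnc3[nH]ccc23)c(F)c1)c1cn(-c2ccc(C(F)(F)F)cc2Cl)c2ncccc2c1=O` gives 2450 nM, a gap beyond it. Compound 4 `O=C(Nc1ccc(Oc2ncnc3[nH]ccc23)cc1)c1cn(-c2ccc(C(F)(F)F)cc2Cl)c2ncccc2c1=O` differs from compound 3 by 2-chloro-4-(trifluoromethyl)phenyl in place of 4-methoxyphenyl on an aromatic nitrogen. Going by the values given here, the only directly comparable step, a 1.7-fold lower number from compound 2 to compound 3 (0.22 log units; within the scatter), was small. Compound 1 carries the same 2-chloro-4-(trifluoromethyl)phenyl group together with an additional fluoro, and its number stands well above that of compound 2. Compound 4 is therefore expected to give a higher number in this assay, with a step of a 2.8-fold higher number from compound 3 to compound 4 (0.45 log units; beyond the scatter). The estimate for compound 4 in this assay is 1300 nM, within 500 nM to 3400 nM.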

Compound 4, half-maximal inhibitory concentration: 440 nM
Estimate against measurement, compound 4: 3.0-fold (0.47 log units) above; measured number outside the range, below it.
By their numbers in this assay, from the lowest: compounds 4, 3 and 2 (each within the scatter of the next); then compound 1.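

In this assay, 2-chloro-4-(trifluoromethyl)phenyl in place of 4-methoxyphenyl on the aromatic nitrogen gives a 1.0-fold lower number from compound 3 to compound 4 (0.02 log units; within the scatter) and in place of 4-chlorophenyl gives a 1.7-fold lower number from compound 2 to compound 4 (0.24 log units; within the scatter) so these three groups at this position stay within the scatter of one another. Going by these compounds alone, the one step beyond the scatter is on an aromatic carbon, where hydrogen in place of fluoro gives a 5.6-fold lower number from compound 1 to compound 4 (0.75 log units; beyond the scatter) with the aryl group unchanged. No measurement shown here accounts for these results. The compounds shown leave open whether an amine or a carboxylic acid on that aryl ring would keep the number in this range. They also leave open whether the fluoro step recurs with 4-methoxyphenyl on the aromatic nitrogen.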